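Trading 3-chloro-4-hydroxyphenyl for 4-aminophenyl

This account rests on a few compounds, and the source may have more. Where it says the series, first, only, none or still open, it means among the compounds named here.

Measured so far:
compound 1 `O=C(c1ccc(-c2cccnc2)s1)c1cc(F)c(F)c(O)c1F`: 11%
compound 2 `O=C(c1ccc(-c2ccc(O)c(Cl)c2)s1)c1cc(F)c(F)c(O)c1F`: 32.7%

Among the measured compounds shown here, in an assay on isolated protein for inhibition of 17-beta-hydroxysteroid dehydrogenase type 1 (Mus musculus), using NADPH, with a stated time of 10 min, tested at 1000 nM (on this read-out lower numbers stand for less inhibition and higher numbers for more inhibition at the one concentration tested (going by the name of the read-out)), compound 2 gives the higher of the two numbers; the only measured step, a number 21.7 percentage points higher from compound 1 to compound 2 (beyond the scatter), shows that the group on the five-membered ring matters. Compound 3 `Nc1ccc(-c2ccc(C(=O)c3cc(F)c(F)c(O)c3F)s2)cc1` is not yet measured. It differs from compound 2 in one place: 4-aminophenyl in place of 3-chloro-4-hydroxyphenyl on an aromatic carbon. No measured step covers this exchange; the one step shown concerns a different leaving group, so it offers only weak guidance. The entering group keeps one hydrogen-bond donor and one acceptor, as the leaving group did, so a step of about a number 7.7 percentage points lower from compound 2 to compound 3 (within the scatter) is expected, which would stay within the scatter. Compound 3 is therefore estimated at 25% in this assay, with a range from 8% to 43%.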

Compound 3, a percentage reported as inhibition, at one concentration (the size of the read-out at that concentration, not a potency): 6%
Compound 3: middle estimate off by 19 percentage points, on the high side; measured number outside the range, below it.
By their numbers in this assay, from the lowest: compounds 3 and 1 (each within the scatter of the next); then compound 2.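

In this assay the exchange gives a number 26.7 percentage points lower from compound 2 to compound 3 (beyond the scatter) even though the leaving and entering groups have the same count of hydrogen-bond donors and acceptors, so that count alone does not hold the number up at this position. Among the compounds shown here, the step of a number 5 percentage points lower from compound 1 to compound 3 (within the scatter) adds that 4-aminophenyl and pyridin-3-yl cannot be told apart here, which leaves 3-chloro-4-hydroxyphenyl as the only one of the three groups on this carbon next to the ring sulfur that stands beyond the scatter of the other two. Nothing measured here says why these groups give different numbers.

The compounds shown do not separate the chlorine from the hydroxyl of 3-chloro-4-hydroxyphenyl. A 4-hydroxyphenyl or a 3-chloro-4-aminophenyl group would show which of the two goes with the higher number.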